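Ester Size and Calcium Channel Antagonism in a Dihydropyridine Series

The source may hold more compounds than are shown below. What is called first, only, known or untested is meant among the compounds shown, and "the series" means these compounds.

Compound 1, `CCOC(=O)C1=C(C)NC(C)=C(C(=O)OCC)C1c1csc(-c2ccc(Cl)cc2)n1`, gives 3650 nM in an assay on isolated protein for antagonist activity at Voltage-dependent L-type calcium channel subunit alpha-1C (Cavia porcellus), with a stated time of 15 min; a lower number here means a stronger inhibitor, a higher number a weaker inhibitor.
Compound 2, `CCOC(=O)C1=C(C)NC(C)=C(C(=O)OC)C1c1csc(-c2ccc(Cl)cc2)n1`, gives 22000 nM in this assay.
Compound 3, `CCOC(=O)C1=C(C)NC(C)=C(C(=O)OC(C)C)C1c1csc(-c2ccc(Cl)cc2)n1`, gives 2550 nM in this assay.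

Compound 3 holds the lowest of the three numbers; its nearest neighbour is compound 1, within the scatter, while compound 2 lies well beyond it. Compound 4, `CCOC(=O)C1=C(C)NC(C)=C(C(=O)OCC(C)C)C1c1csc(-c2ccc(Cl)cc2)n1`, differs from compound 3 by isobutyl in place of isopropyl on an oxygen next to a carbonyl group. The measured steps that bear on this change all alter the same ester group: an 8.6-fold lower number from compound 2 to compound 3 (0.94 log units; beyond the scatter) and a 6.0-fold higher number from compound 1 to compound 2 (0.78 log units; beyond the scatter) were both modest and beyond the scatter, whereas a 1.4-fold lower number from compound 1 to compound 3 (0.16 log units; within the scatter) stayed within it. The gain from enlarging the ester therefore appears to flatten once the group reaches ethyl, so a further step to isobutyl is expected to move this assay little, if at all, beyond the scatter, perhaps slightly lower. Compound 4 is thus estimated at 2000 nM, with a range of 700 nM to 6000 nM, which is expected to mean a 1.3-fold lower number from compound 3 to compound 4 (0.11 log units; within the scatter).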

Compound 4, half-maximal inhibitory concentration: 15400 nM
Compound 4: middle estimate off by 7.7-fold (0.89 log units), on the low side; measured number above the stated range.
By their numbers in this assay, from the lowest: compounds 3 and 1 (each within the scatter of the next); then compounds 4 and 2 (each within the scatter of the next).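

In this assay, this ester position does not simply reward a larger group: the change from isopropyl to isobutyl gave a 6.0-fold higher number from compound 3 to compound 4 (0.78 log units; beyond the scatter), and the change from ethyl to isobutyl gave a 4.2-fold higher number from compound 1 to compound 4 (0.63 log units; beyond the scatter). With a 1.4-fold lower number from compound 2 to compound 4 (0.15 log units; within the scatter), the isobutyl ester returns to within the scatter of the methyl ester, so among these four compounds the numbers are lowest for the ethyl and isopropyl esters, and the levelling seen between compound 1 and compound 3 does not carry on to isobutyl. Nothing measured here accounts for this reversal.

The compounds shown leave open whether the isobutyl result reflects chain length or branching, a question that straight propyl and butyl esters or a tert-butyl ester could address. They also leave open how a benzyl ester would read at this position.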